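Swapping Pyridin-3-yl for 4-Hydroxyphenyl

The compounds below may be only part of what the source reports. "The series", "measured", "known", "first", "only" and "open" are said of these compounds alone.

Compound 1 `COc1ccc(S(=O)(=O)N2CCc3cccc(-c4ccc(N)cc4)c32)cc1`: 162 nM
Compound 2 `COc1ccc(S(=O)(=O)N2CCc3cccc(-c4cccnc4)c32)cc1`: 68.5 nM

In a functional assay on MKN-45 cells (Homo sapiens) for inhibition, with a stated time of 72 h (on this read-out lower numbers stand for stronger inhibition and higher numbers for weaker inhibition), compound 2 gives the lower of the two numbers, 68.5 nM. The next compound, compound 3 `COc1ccc(S(=O)(=O)N2CCc3cccc(-c4ccc(O)cc4)c32)cc1`, carries 4-hydroxyphenyl in place of pyridin-3-yl on the shared core: 4-hydroxyphenyl in place of pyridin-3-yl on an aromatic carbon. Among the measured compounds shown here, only one measured step bears on this change: a 2.4-fold lower number from compound 1 to compound 2 (0.37 log units; beyond the scatter). That step joins the same pyridin-3-yl to 4-aminophenyl, which, like 4-hydroxyphenyl, is a phenyl group with one added substituent. For the measured compounds named here, compound 1 is therefore the closest guide, although no measured compound carries 4-hydroxyphenyl itself. A modest move to a higher number in this assay is expected, of about the size of the measured step taken in reverse. The expected step is a 2.0-fold higher number from compound 2 to compound 3 (0.31 log units; beyond the scatter). Compound 3 is estimated at 140 nM. Its expected range runs from 45 nM to 420 nM.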

Compound 3, half-maximal inhibitory concentration: 82.6 nM
Beside the measured number, compound 3's estimate is 1.7-fold (0.23 log units) above it; the measured number falls inside the stated range.
By their numbers in this assay, from the lowest: compounds 2, 3 and 1 (each within the scatter of the next, the first and the last beyond it).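

In this assay, exchanging pyridin-3-yl for 4-hydroxyphenyl gives a 1.2-fold higher number from compound 2 to compound 3 (0.08 log units; within the scatter), so at this aromatic carbon the two groups cannot be told apart, even though one ring holds a nitrogen and the other is of carbon only and bears a hydroxy group. Hydroxy in place of amino gives a 2.0-fold lower number from compound 1 to compound 3 (0.29 log units; within the scatter), so compound 3 lies within the scatter of both compound 1 and compound 2, and the step beyond the scatter seen earlier does not extend to every phenyl group with one added substituent. Nothing available here accounts for these numbers.

From the compounds shown here alone, whether a carboxylic acid or a methoxy group on the same phenyl ring would fit with these results remains open. Going by these compounds, it is also open how a pyridin-4-yl group, or a hydroxy group elsewhere on that ring, would compare with compound 3.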